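The compounds below may be only part of what the source reports. "The series", "measured", "known", "first", "only" and "open" are said of these compounds alone.

The two measured compounds share one core. Compound 1, `COc1cc(/C=C/C(=O)c2cccc(-n3cc(-c4ccccc4)[nH]c3=O)c2)ccc1O`, gives 3900 nM in a functional assay on SNB-75 cells (Homo sapiens) for inhibition; on this read-out higher numbers stand for weaker inhibition of growth and lower numbers for stronger inhibition of growth. Compound 2, `O=C(/C=C/c1cccc(O)c1)c1cccc(-n2cc(-c3ccccc3)[nH]c2=O)c1`, gives 12100 nM in the same assay, and stands highest of the two numbers shown; the only measured step, a 3.1-fold higher number from compound 1 to compound 2 (0.49 log units; beyond the scatter), lies beyond the scatter and concerns the aryl group on the double-bonded chain.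

Compound 3, `O=C(/C=C/c1cccc(O)c1)c1cccc(-n2cc(-c3ccc(Cl)cc3)[nH]c2=O)c1`, differs from compound 2 in a single place: chloro in place of hydrogen on an aromatic carbon. For the measured compounds named here, the one measured step, from compound 1 to compound 2, changes the aryl group on the chain, not the phenyl on the core, so no measured step bears on the change from compound 2 to compound 3. With nothing to go on for this position, the expectation is a step of no clear direction, likely within the scatter, a 1.0-fold lower number from compound 2 to compound 3 (0.00 log units; within the scatter). Compound 3 is therefore estimated at 12000 nM in this assay, with a range from 5000 nM to 30000 nM.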

Compound 3, concentration for 50% growth inhibition: 1460 nM
Beside the measured number, compound 3's estimate is 8.2-fold (0.91 log units) above it, and the stated range ends above it.
By their numbers in this assay, from the lowest: compound 3; then compound 1; then compound 2.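

In this assay, the change from phenyl to 4-chlorophenyl gives an 8.3-fold lower number from compound 2 to compound 3 (0.92 log units; beyond the scatter), which shows that this place on the shared core, an aromatic carbon para to a large group, responds to substitution, with stronger inhibition of growth on adding chloro. For the compounds shown here, the only earlier step, a 3.1-fold higher number from compound 1 to compound 2 (0.49 log units; beyond the scatter), concerned the aryl group on the chain, so the series now has two places where a single change moves the number beyond the scatter, and this is the first to show a lower number. Nothing shown accounts for why a single chlorine atom at this place has this effect.

The compounds shown leave open whether chloro at this place would lower the number to the same degree with the 4-hydroxy-3-methoxyphenyl group of compound 1 on the chain, since the chloro change is seen only with the 3-hydroxyphenyl group. They also leave open whether the response is specific to chloro or would extend to another group at the same carbon, such as bromo, an amine or a carboxylic acid.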